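Moving a nitro group to the para position of the benzyl ether

The source may hold more compounds than are shown below. What is called first, only, known or untested is meant among the compounds shown, and "the series" means these compounds.

Compound 1 `COc1cccc(OC)c1OCCNCCOc1ccccc1OCc1ccccc1Cl` is the more potent of the two compounds measured in a functional assay on Vas deferens for antagonist activity at Alpha-1A adrenergic receptor (Rattus norvegicus) (a lower number here means a less potent compound, a higher number a more potent compound, by a factor of ten per unit of this negative logarithm), where compound 1 gives 8.56. For the measured compounds named here, its only measured neighbour, compound 2 `COc1cccc(OC)c1OCCNCCOc1ccccc1OCc1ccccc1[N+](=O)[O-]`, gives 8.2 in this assay, so that the step of a number 0.36 log units lower from compound 1 to compound 2 (beyond the scatter) is the single piece of evidence on what a nitro group does to this series when it stands in place of the chlorine.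

Compound 3 `COc1cccc(OC)c1OCCNCCOc1ccccc1OCc1ccc([N+](=O)[O-])cc1` is not yet measured. It differs from compound 1 as follows: 4-nitrophenyl in place of 2-chlorophenyl on a saturated chain carbon bound to an oxygen on an aromatic ring. Going by the values given here, the change bears a resemblance to the measured step, since in both cases a nitro group enters and the chlorine leaves, but in compound 3 the nitro group sits at a different position on the ring, which no measured pair covers. Among the compounds with values here, the one relevant step was a modest loss, and a loss of similar size is expected here, with wider uncertainty because the position is new. For compound 3 the estimate in this assay is 8.1, between 7.5 and 8.6, which corresponds to an expected step of a number 0.46 log units lower from compound 1 to compound 3 (beyond the scatter).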

Compound 3, negative logarithm of the antagonist equilibrium constant: 8.58
Compound 3: middle estimate off by 0.48 log units, on the low side; the measured number falls inside the stated range.
By their numbers in this assay, from the lowest: compound 2; then compounds 1 and 3 (each within the scatter of the next).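

In this assay the 4-nitrophenyl group of compound 3 and the 2-chlorophenyl group of compound 1 cannot be told apart, with a step of a number 0.02 log units higher from compound 1 to compound 3 (within the scatter), so a nitro group on this ring does not by itself bring a loss in this series. The comparison between the two nitro compounds, which shows a number 0.38 log units higher from compound 2 to compound 3 (beyond the scatter), adds what the earlier pair could not: in these compounds the place of the nitro group on the ring matters, and the lower number belongs to the 2-nitrophenyl group of compound 2 rather than to the nitro group as such. Nothing available here accounts for this difference between the two nitro compounds.

On these data alone, whether a chlorine at the ring place the nitro group holds in compound 3 would keep the number of compound 1 stays open, so the effects of the group and of its place are only partly separated. As far as these compounds go, it is also open what an amine or a carboxylic acid in place of that nitro group would give.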